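Acyl swap on the amide side chain: methyl to tert-butyl

The source may hold more compounds than are shown below. What is called first, only, known or untested is meant among the compounds shown, and "the series" means these compounds.

Measured in a functional assay on CCRF-CEM cells (Homo sapiens) for inhibition; a lower number here means a stronger inhibitor, a higher number a weaker inhibitor:
- compound 1 `Cn1cc(C#N)c2ccc(Nc3ncc(-c4ccccc4)o3)cc21`: 8000 nM
- compound 2 `Cn1cc(C#N)c2ccc(Nc3ncc(-c4ccc(CNC(=O)c5ccccc5)cc4)o3)cc21`: > 10000 nM (a limit)
- compound 3 `CC(=O)NCc1ccc(-c2cnc(Nc3ccc4c(C#N)cn(C)c4c3)o2)cc1`: > 10000 nM (a limit)

Only compound 1 has a number. The entry for compound 3 is a limit, > 10000 nM, and the series shows (the limit of > 10000 nM in this assay, at which 2 of the 3 values shown sit).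

Compound 4 `Cn1cc(C#N)c2ccc(Nc3ncc(-c4ccc(CNC(=O)C(C)(C)C)cc4)o3)cc21` differs from compound 3 by tert-butyl in place of methyl on a carbonyl carbon.

Within the data shown here, three measured steps bear on this change. The closest also changes the group on the carbonyl carbon, methyl in place of phenyl, and it is a step that the two limits leave unreadable from compound 2 to compound 3. It therefore gives no size to carry over. The other two add the amide side chain to the core of compound 1: an at least 1.2-fold higher number from compound 1 to compound 2 (0.09 log units; that floor lies within the scatter), and an at least 1.2-fold higher number from compound 1 to compound 3 (0.09 log units; that floor lies within the scatter). Neither gives a step beyond the scatter that could be transferred to the new group.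

No readable step in this assay is therefore expected in either direction, and compound 4 will most likely also be reported only as a limit. The expected step is a step that the limit leaves unreadable from compound 3 to compound 4. The estimated value for compound 4 is 12000 nM, with an expected range from 6000 nM to 30000 nM.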

Compound 4, half-maximal inhibitory concentration: 4900 nM
Beside the measured number, compound 4's estimate is 2.4-fold (0.39 log units) above it; the measured number lies below the stated range.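

In this assay compound 4, with tert-butyl on the carbonyl carbon, is the only compound bearing the amide side chain that reads as a number and not as a limit, while the methyl and phenyl amides stay at the ceiling: the limit of > 10000 nM in this assay, at which 2 of the 4 values shown sit.

Against those two amides the change reads as an at least 2.0-fold lower number from compound 3 to compound 4 (0.30 log units; that floor lies within the scatter) and as an at least 2.0-fold lower number from compound 2 to compound 4 (0.30 log units; that floor lies within the scatter), so both floors stay inside the scatter and neither establishes a gain from the tert-butyl group. Against the core without the side chain there is a 1.6-fold lower number from compound 1 to compound 4 (0.21 log units; within the scatter), which shows that this side chain, capped with tert-butyl, can be carried with no readable change, something the two limits could not show.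

Going by these compounds, neither the methyl nor the phenyl amide has a number, so the true size of both steps to tert-butyl stays open. Also open, on these data alone, is whether an amine, a carboxylic acid or a longer chain on this carbonyl carbon would move the value beyond the scatter in either direction.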